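The source may report more compounds than this note shows. Statements on the series, on what has been measured and on what is new or still open speak of the compounds shown alone.

Measured so far, all in a functional assay on SK-MEL-28 cells (Homo sapiens) for inhibition, read by MTT assay, with a stated time of 72 h; a higher number here means a weaker inhibitor of growth, a lower number a stronger inhibitor of growth:
- compound 1, `CC(C)=CCC/C(C)=C/CC/C(C)=C/C(=O)NC(=N)N`: 20100 nM
- compound 2, `C=C1CCCC(C)(C)[C@@H]1CC/C(C)=C/C(=O)NC(=N)NC(=O)C=C(C)C`: 60500 nM
- compound 3, `CC(C)=CCC/C(C)=C/CC/C(C)=C/C(=O)NC(=N)NC(=O)C=C(C)C`: 24200 nM

Compound 1 gives the lowest of the three numbers. Its nearest neighbour is compound 3, where the (2-methylprop-1-en-1-yl)carbonyl in place of hydrogen on an amine nitrogen moved the number by a 1.2-fold higher number from compound 1 to compound 3 (0.08 log units; within the scatter), so within the scatter. Among the measured compounds shown here, compound 2 stands furthest from compound 1; its number is higher, beyond the scatter, but no single-point step links it to compound 1 and compound 2 and compound 3 differ in the chain, so what its value shows is only that the cyclised analogue sits weaker in this assay.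

Compound 4, `CC(C)=CCC/C(C)=C/C(=O)NC(=N)N`, is not yet measured. It differs from compound 1 by hydrogen in place of 3-methylbut-2-en-1-yl on a saturated chain carbon bound to a double-bonded chain carbon

For the measured compounds named here, no measured step bears on a change of this kind: the one step available, from compound 1 to compound 3, alters the nitrogen end and not the chain, and it lay within the scatter. With the chain shortened by the 3-methylbut-2-en-1-yl group, a modest loss is expected rather than a gain, but the support is thin. For compound 4 the expected number is 35000 nM with a range of 12000 nM to 100000 nM, a step of a 1.7-fold higher number from compound 1 to compound 4 (0.24 log units; within the scatter) that is expected to be small.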

Compound 4, concentration for 50% growth inhibition: 56300 nM
Beside the measured number, compound 4's estimate is 1.6-fold (0.21 log units) below it; the measured number falls inside the stated range.
By their numbers in this assay, from the lowest: compounds 1 and 3 (each within the scatter of the next); then compounds 4 and 2 (each within the scatter of the next).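

In this assay, the change to hydrogen in place of 3-methylbut-2-en-1-yl on a saturated chain carbon bound to a double-bonded chain carbon gives a 2.8-fold higher number from compound 1 to compound 4 (0.45 log units; beyond the scatter). Among the compounds shown here, this is the first step to lie beyond the scatter and the first to alter the chain, whereas the change at the nitrogen end, a 1.2-fold higher number from compound 1 to compound 3 (0.08 log units; within the scatter), lay within it. So the 3-methylbut-2-en-1-yl group at this position counts for growth inhibition in this series, at least on the core of compound 1, although no data on hand explain the size of the step.

Still open, as far as these compounds go, is whether the number keeps falling with a longer chain carrying a further 3-methylbut-2-en-1-yl group, or whether a saturated chain of the same length as in compound 1 would serve equally well, since one step cannot separate chain length from the double bond that leaves with the group. Also open, from the compounds shown here alone, is whether the (2-methylprop-1-en-1-yl)carbonyl group remains without a clear effect on the shorter chain of compound 4, or whether a simple acetyl group at that nitrogen behaves the same way.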